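A Carbamoyl in Place of Methanesulfonamido

The source may hold more compounds than are shown below. What is called first, only, known or untested is meant among the compounds shown, and "the series" means these compounds.

compound 1, `FC(F)(F)Oc1ccc(Nc2cc(-n3ccnc3)ncn2)cc1`: > 10000 nM
compound 2, `CS(=O)(=O)Nc1ccc(-c2cc(Nc3ccc(OC(F)(F)F)cc3)ncn2)cc1`: 2210 nM

Among the measured compounds shown here, in an ADME assay on BaF3 cells (Mus musculus) for cytotoxicity (on this read-out higher numbers stand for an effect only at larger amounts of compound and lower numbers for an effect already at smaller amounts), compound 2 gives 2210 nM, which is the only actual number among the two values shown. Compound 1 instead sits at the limit of > 10000 nM in this assay, at which 1 of the 2 values shown sits; this is a limit of the assay and not a measured number. Compound 3, `NC(=O)c1ccc(-c2cc(Nc3ccc(OC(F)(F)F)cc3)ncn2)cc1`, is still to be measured in this assay. It differs from compound 2 in a single place: carbamoyl in place of methanesulfonamido on an aromatic carbon. For the measured compounds named here, no pair of measured compounds shows a change of this kind, and the data therefore give no size for such a step. The change leaves everything else in compound 2 untouched, and the step from compound 2 to compound 3 is expected to be small, with no clear direction beyond the usual scatter: a 1.1-fold higher number from compound 2 to compound 3 (0.05 log units; within the scatter). Compound 3 is estimated at 2500 nM in this assay, with a likely range from 800 nM to 8000 nM.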

Compound 3, half-maximal effective concentration: > 10000 nM
Compound 3 ended at the assay's limit; the forecaster's own chance of this, stated with the estimate: 15%; at least 4.0-fold (0.60 log units) between middle value and limit.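

Among the compounds shown here, this is the first change at this position whose size can be read: in this assay, carbamoyl in place of methanesulfonamido gives an at least 4.5-fold higher number from compound 2 to compound 3 (0.65 log units; beyond the scatter). The group at this position therefore matters for this read-out, and so far compound 2, with methanesulfonamido, is the only one of the compounds shown to give an actual number rather than a limit. Compound 3 sits at a limit of the assay, not at a measured number, and it shares that limit with compound 1, so the step between those two cannot be read: the limit of > 10000 nM in this assay, at which 2 of the 3 values shown sit.

On these data alone, how far beyond the limit compound 3 lies stays open. Also open, as far as these compounds go, is what a carboxylic acid, an amine or a methyl sulfone at the same position would give, and so which part of methanesulfonamido counts.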